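From 1-acetylpyrrolidin-2-yl to 2-oxopyrrolidin-1-yl on a shared core

The source may report more compounds than this note shows. Statements on the series, on what has been measured and on what is new or still open speak of the compounds shown alone.

Measured so far in a physicochemical assay for solubility, read by nephelometry, in phosphate buffer, at pH 7.4; a higher number here means a more soluble compound, a lower number a less soluble compound:
- compound 1 `CC(=O)N1CCCC1c1cc(C(=O)Nc2nc3c(s2)CCC3)c(C)s1` gives 7810 nM as its reading
- compound 2 `CC(=O)N1CCCCC1c1cc(C(=O)Nc2nc3c(s2)CCC3)c(C)s1` gives 980 nM as its reading

Of these two, compound 1 stands highest, with 7810 nM against compound 2 at 980 nM in the same test, a gap beyond the usual scatter. Attention now turns to compound 3 `Cc1sc(N2CCCC2=O)cc1C(=O)Nc1nc2c(s1)CCC2`, which has not yet been measured. It carries 2-oxopyrrolidin-1-yl in place of 1-acetylpyrrolidin-2-yl on an aromatic carbon, next to the ring sulfur. The count of the change from compound 1 reads: 2-oxopyrrolidin-1-yl in place of 1-acetylpyrrolidin-2-yl on an aromatic carbon. Among the compounds with values here, no measured pair isolates this change, so the expectation rests on little. Since compound 1 holds the top number of a very small set, a moderate move to a lower number in this assay is expected, probably just beyond the scatter. The estimated change is a 2.6-fold lower number from compound 1 to compound 3 (0.42 log units; beyond the scatter) in this reading. For compound 3 the expected solubility is 3000 nM, with an estimated range from 800 nM to 11000 nM around it.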

Compound 3, solubility: 3910 nM
The estimate for compound 3 lay 1.3-fold (0.12 log units) below the measured number; low and high end bracket the measured number.
By their numbers in this assay, from the lowest: compound 2; then compounds 3 and 1 (each within the scatter of the next).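

Within the data shown here, with the first step at this position that changes a single group, this assay gives a 2.0-fold lower number from compound 1 to compound 3 (0.30 log units; within the scatter) for 2-oxopyrrolidin-1-yl in place of 1-acetylpyrrolidin-2-yl, on an aromatic carbon next to the ring sulfur. The group that enters has 6 heavy atoms and the group that leaves has 8, and both have one five-membered non-aromatic ring and 1 hydrogen-bond acceptor, so on this core the exchange leaves two readings that cannot be told apart. Nothing among the data given explains that outcome, and no cause can be assigned to it.

The compounds shown leave open how this assay would respond at this position to a group without a non-aromatic ring, such as a primary amine, a carboxylic acid or a longer alkyl chain. They also leave open whether 2-oxopiperidin-1-yl, the six-membered counterpart of the group in compound 3, would give a reading close to that of compound 3, since a single step cannot show how far this result extends.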